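Trimethoxyanilino benzoxazoles: extending the ortho-substituted pendant ring

The source may report more compounds than this note shows. Statements on the series, on what has been measured and on what is new or still open speak of the compounds shown alone.

Compound 1 `COc1ccc(Nc2nc3cccc(-c4c(F)cccc4OC)c3o2)cc1`: 1400 nM
Compound 2 `COc1cccc(F)c1-c1cccc2nc(Nc3cccc(S(N)(=O)=O)c3)oc12`: 340 nM
Compound 3 `COc1ccccc1-c1cccc2nc(Nc3cc(OC)c(OC)c(OC)c3)oc12`: 20 nM

Of the compounds shown here, three have been measured in an assay on isolated protein for inhibition of ribosomal protein S6 kinase alpha-2 (Homo sapiens), with a stated time of 150 min; on this read-out higher numbers stand for weaker inhibition and lower numbers for stronger inhibition. Compound 3 gives the lowest number of the three, at 20 nM; compound 2 stands nearest with 340 nM, a gap that lies beyond the scatter, and compound 1 stands furthest with 1400 nM, also beyond the scatter. For the measured compounds named here, compounds 1 and 2 differ from compound 3 in more than one place, so no single-place step between measured compounds is available, and their numbers show only that compound 3 is the strongest inhibitor of the three.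

Compound 4 `CCOc1cccc(F)c1-c1cccc2nc(Nc3cc(OC)c(OC)c(OC)c3)oc12` has not yet been measured. It differs from compound 3 in one place: 2-ethoxy-6-fluorophenyl in place of 2-methoxyphenyl on an aromatic carbon. The pendant ring thus gains a fluorine and a longer alkoxy chain while the trimethoxyanilino part of compound 3 is kept. Going by the values given here, with no measured step of this kind to lean on, the expectation for the step from compound 3 to compound 4 in this assay is a modest rise in the number, a 2.0-fold higher number from compound 3 to compound 4 (0.30 log units; within the scatter), possibly within the scatter. On this basis compound 4 is estimated at 40 nM, within a range from 10 nM to 160 nM.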

Compound 4, half-maximal inhibitory concentration: 490 nM
Estimate against measurement, compound 4: 12-fold (1.09 log units) below; measured number outside the range, above it.
By their numbers in this assay, from the lowest: compound 3; then compounds 2 and 4 (each within the scatter of the next); then compound 1.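

In this assay, putting 2-ethoxy-6-fluorophenyl in place of 2-methoxyphenyl on an aromatic carbon gives a 25-fold higher number from compound 3 to compound 4 (1.39 log units; beyond the scatter), the first single-place step available in this set, and it shows that the number responds strongly to a change at this position. The earlier compounds shown here differ from one another in more than one place and could not isolate the pendant ring, whereas this step holds the trimethoxyanilino part constant and shows that this part alone does not secure the low number of compound 3. No measurement at hand bears on why the number rises so far with this change.

The change brings in a fluorine and lengthens the alkoxy chain at once, so the compounds shown leave open how much of the step belongs to each, a question that a 2-ethoxyphenyl ring or a 2-fluoro-6-methoxyphenyl ring on the same trimethoxyanilino-bearing core would address. Also open, going by these compounds, is how the number would respond to a pendant ring carrying a hydroxyl group, an amine or a longer chain such as propoxy in place of the methoxy group of compound 3.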